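Swapping Chloro for Methyl on the Arylamino Group

This account rests on a few compounds, and the source may have more. Where it says the series, first, only, none or still open, it means among the compounds named here.

Of the compounds shown here, two sharing one core have been tested in a functional assay on A-431 cells (Homo sapiens) for antiproliferative activity, read by MTT assay, with a stated time of 72 h; on this read-out higher numbers stand for weaker inhibition and lower numbers for stronger inhibition. Compound 1 `NS(=O)(=O)c1ccc(NC(=S)Nc2ccc3ncnc(Nc4ccc(C(F)(F)F)cc4)c3c2)cc1` gives 18000 nM in this assay. Compound 2 `NS(=O)(=O)c1ccc(NC(=S)Nc2ccc3ncnc(Nc4cccc(Cl)c4)c3c2)cc1`, which carries 3-chlorophenyl in place of 4-(trifluoromethyl)phenyl on a nitrogen on an aromatic ring, gives 15000 nM in this assay. The step of a 1.2-fold lower number from compound 1 to compound 2 (0.08 log units; within the scatter) is the only one measured so far, and it lies within the scatter, so compound 2 holds the lowest of the two numbers shown without being separable from compound 1. Compound 3 `Cc1cccc(Nc2ncnc3ccc(NC(=S)Nc4ccc(S(N)(=O)=O)cc4)cc23)c1` is the next member: relative to compound 2 it shows (methyl in place of chloro on an aromatic carbon). Going by the values given here, no measured step covers this exact exchange; the one step that exists, a 1.2-fold lower number from compound 1 to compound 2 (0.08 log units; within the scatter), replaced a whole aryl group and still produced no movement beyond the scatter. On that basis the step is expected to stay within the scatter, no change at the digits printed from compound 2 to compound 3 (within the scatter). Compound 3 is therefore estimated at 15000 nM in this assay, with a range from 6000 nM to 40000 nM.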

Compound 3, half-maximal inhibitory concentration: 23800 nM
Estimate against measurement, compound 3: 1.6-fold (0.20 log units) below; measured number inside the range.
By their numbers in this assay, from the lowest: compounds 2, 1 and 3 (each within the scatter of the next).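

In this assay, the exchange of chloro for methyl on an aromatic carbon, meta to a large group, gives a 1.6-fold higher number from compound 2 to compound 3 (0.20 log units; within the scatter), so this change of one heavy atom for another cannot be told apart from no change on this read-out. Going by these compounds alone, the earlier compounds offered only one exchange on the arylamino nitrogen, whereas the step of a 1.3-fold higher number from compound 1 to compound 3 (0.12 log units; within the scatter) now adds a second comparison with the 4-(trifluoromethyl)phenyl compound, and all three aryl groups, 4-(trifluoromethyl)phenyl, 3-chlorophenyl and 3-methylphenyl, stand within the scatter of one another. Nothing available explains why these numbers stay so close together.

The compounds shown leave open whether a group of another kind on this ring, such as an amine, a carboxylic acid or a longer alkoxy chain, would move the number beyond the scatter. They also leave open how much the number depends on the sulfonamide-bearing part of the molecule, which is the same in all three compounds, so none of these steps speaks to a change made there.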